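Cytotoxicity readings for compounds 1 to 4

A few compounds are considered here, and "the series" means these few. Any claim that something is new, unique, unknown or untested is made for them only; others in the source may bear on it.

Three members of the series have been read in an ADME assay on L929 cells (Mus musculus) for cytotoxicity, read by resazurin assay, with a stated time of 72 h; a lower number here means a stronger inhibitor, a higher number a weaker inhibitor. Compound 1 `COCOc1cccc(C(=O)/C=C/c2ccc3c(c2)B(O)OC3)c1` is reported in this assay only as a limit, > 10 ug/mL. Compound 2 `O=C(/C=C/c1ccc2c(c1)B(O)OC2)c1ccc(OCc2ccccc2)cc1` likewise returns only a limit in this assay, > 10 ug/mL. Compound 3 `O=C(/C=C/c1ccc2c(c1)B(O)OC2)c1cccs1` gives a limit as well in this assay, > 10 ug/mL. No numbered value exists for any of the three; all sit at the limit of > 10 ug/mL in this assay, at which 3 of the 3 values shown sit, so compound 2 stands exactly where every other measured member stands, and no ordering among them can be drawn from these readings.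

Compound 4 `COc1ccc(C(=O)/C=C/c2ccc3c(c2)B(O)OC3)cc1` is the next member to be read in this assay. It differs from compound 2 in one place: hydrogen in place of phenyl on a saturated chain carbon bound to an oxygen on an aromatic ring. Among the compounds with values here, no step between measured compounds exists to calibrate this change. Since compound 1, compound 2 and compound 3 all sit at the limit of > 10 ug/mL in this assay, at which 3 of the 3 values shown sit, despite the differences among their structures, the expectation is that compound 4 also shows no measurable inhibition in this assay. The step from compound 2 to compound 4 is expected to be none beyond the scatter, a step that the limit leaves unreadable from compound 2 to compound 4, with the likely outcome again a limit rather than a number. For compound 4 the estimate is 20 ug/mL, within 10 ug/mL to 50 ug/mL.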

Compound 4, half-maximal inhibitory concentration: > 10 ug/mL
Compound 4: no number, only a limit (the forecaster's own chance of this, stated with the estimate: 85%); the middle value does not contradict the limit.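

Compound 2 and compound 4 both return only limits in this assay, so no step can be read for the change from benzyloxy to methoxy. The compounds shown leave open how any member of the series ranks in this assay, and at what concentration, if any, cytotoxicity appears, with every reading still at one limit: the limit of > 10 ug/mL in this assay, at which 4 of the 4 values shown sit.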